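Swapping a sulfur-bearing ring for a cyclic imide

The source may report more compounds than this note shows. Statements on the series, on what has been measured and on what is new or still open speak of the compounds shown alone.

Measured compounds:
compound 1, `Cc1nc(N2CCC(NS(=O)(=O)N(C)C)CC2)nc2ccc(NC(=O)/C=C/c3ccc(OC(F)(F)F)cc3)cc12`, 105 nM
compound 2, `Cc1nc(N2CCC(N3CCOC3=O)CC2)nc2ccc(NC(=O)/C=C/c3ccc(OC(F)(F)F)cc3)cc12`, 41 nM
compound 3, `Cc1nc(N2CCC(N3CCCS3(=O)=O)CC2)nc2ccc(NC(=O)/C=C/c3ccc(OC(F)(F)F)cc3)cc12`, 4 nM

All three share one core and differ only in the group on a saturated ring carbon of the six-membered ring. In an assay on CHO-K1 cells for displacement of a labelled ligand from melanin-concentrating hormone receptor 1 (Homo sapiens), read by scintillation proximity assay, with a stated time of 2 h (a higher number here means a weaker inhibitor, a lower number a stronger inhibitor), compound 3 gives the lowest of the three numbers, and both of its steps lie beyond the scatter: a 26-fold lower number from compound 1 to compound 3 (1.42 log units; beyond the scatter) and a 10-fold lower number from compound 2 to compound 3 (1.01 log units; beyond the scatter).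

Compound 4, `Cc1nc(N2CCC(N3C(=O)CCC3=O)CC2)nc2ccc(NC(=O)/C=C/c3ccc(OC(F)(F)F)cc3)cc12`, takes the next step: a group of 7 heavy atoms (4 carbon, 1 nitrogen, 2 oxygen; one five-membered non-aromatic ring with 1 hetero atom) in place of a group of 7 heavy atoms (3 carbon, 1 nitrogen, 2 oxygen, 1 sulfur; one five-membered non-aromatic ring with 2 hetero atoms), on a saturated ring carbon. The group that enters, 2,5-dioxopyrrolidin-1-yl, keeps the five-membered ring and the two hydrogen-bond acceptors but loses the sulfur, and in that respect it sits closer to the ring in compound 2 than to the ring in compound 3.

The step that bears most on this is a 10-fold lower number from compound 2 to compound 3 (1.01 log units; beyond the scatter), where the sulfur-bearing ring replaced a ring without sulfur and the number fell by a large amount. Removing the sulfur again in compound 4 is therefore expected to move the number upward, though the new ring is not the same as that of compound 2, so the size is uncertain. The estimated step is a 7.5-fold higher number from compound 3 to compound 4 (0.88 log units; beyond the scatter), and compound 4 is expected to give about 30 nM, within a range from 8 nM to 120 nM.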

Compound 4, half-maximal inhibitory concentration: 94 nM
Beside the measured number, compound 4's estimate is 3.1-fold (0.50 log units) below it, and the stated range covers the measured number.
By their numbers in this assay, from the lowest: compound 3; then compound 2; then compounds 4 and 1 (each within the scatter of the next).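

Two five-membered rings that match in heavy-atom count and in hydrogen-bond acceptors still differ sharply in this assay: placing 2,5-dioxopyrrolidin-1-yl on this saturated ring carbon instead of the sulfur-bearing ring gives a 24-fold higher number from compound 3 to compound 4 (1.37 log units; beyond the scatter), so these matching counts do not preserve the low number. Changing one ring without sulfur for another matters far less, at a 2.3-fold higher number from compound 2 to compound 4 (0.36 log units; beyond the scatter), which places the sulfur-bearing ring apart from both rings that lack sulfur. Sulfur alone does not set that ring apart, however, since the open-chain (dimethylsulfamoyl)amino group, which also carries sulfur, and the ring without sulfur show a 1.1-fold lower number from compound 1 to compound 4 (0.05 log units; within the scatter).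

Nothing measured here explains why the sulfur-bearing ring stands apart from the other groups at this position. The compounds shown leave open whether the low number depends on the ring size or on the sulfur with its two oxygens, a question that a six-membered ring carrying the same sulfur and oxygens, or 2-oxopyrrolidin-1-yl with a single carbonyl, could help to separate.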